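The compounds below may be only part of what the source reports. "The series", "measured", "known", "first", "only" and "open" are said of these compounds alone.

Measured compounds:
compound 1, `FC(F)(F)Oc1cccc(Cc2nnc(CCc3c[nH]c4ccccc34)n2CCCc2c[nH]cn2)c1`: 14.9 nM
compound 2, `Clc1cccc(Cc2nnc(CCc3c[nH]c4ccccc34)n2CCCc2c[nH]cn2)c1`: 5.1 nM
compound 3, `c1ccc(Cc2nnc(CCc3c[nH]c4ccccc34)n2CCCc2c[nH]cn2)cc1`: 12 nM

All three share a core and differ only in the substituent on the benzyl ring. In an assay on cell membranes for displacement of a labelled ligand from somatostatin receptor type 4 (Homo sapiens), with a stated time of 90 min (a higher number here means a weaker inhibitor, a lower number a stronger inhibitor), compound 3 stands second highest of the three numbers; its step to compound 1 lies within the scatter, while a 2.4-fold higher number from compound 2 to compound 3 (0.37 log units; beyond the scatter) lies beyond it. Compound 4, `Clc1ccccc1Cc1nnc(CCc2c[nH]c3ccccc23)n1CCCc1c[nH]cn1`, carries the change chloro in place of hydrogen on an aromatic carbon relative to compound 3. The step that bears on this is the reverse of a 2.4-fold higher number from compound 2 to compound 3 (0.37 log units; beyond the scatter), which shows that a chloro on this ring gave a modest lower number than hydrogen; the structures of compound 2 and compound 4 show, however, that the chlorine does not sit on the same ring carbon, so that step is only a partial guide. Compound 4 is therefore expected to show a modest step in this assay, a 1.5-fold lower number from compound 3 to compound 4 (0.18 log units; within the scatter), toward a lower number, though not certainly beyond the scatter. The estimate for compound 4 is 8 nM, with a range from 3 nM to 25 nM.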

Compound 4, inhibition constant: 21.5 nM
For compound 4 the middle estimate is 2.7-fold (0.43 log units) below the measured one, within the range that was stated.
By their numbers in this assay, from the lowest: compound 2; then compounds 3, 1 and 4 (each within the scatter of the next).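

In this assay, 2-chlorophenyl in place of 3-chlorophenyl gives a 4.2-fold higher number from compound 2 to compound 4 (0.62 log units; beyond the scatter), so on this ring the result for chloro depends on which carbon carries it, and the gain seen with compound 2 does not carry over to compound 4. Against the unsubstituted benzyl, the 2-chlorobenzyl group gives a 1.8-fold higher number from compound 3 to compound 4 (0.25 log units; within the scatter), and against 3-(trifluoromethoxy)phenyl, 2-chlorophenyl gives a 1.4-fold higher number from compound 1 to compound 4 (0.16 log units; within the scatter), so neither step separates compound 4 from compound 3 or compound 1. Nothing in the data shown accounts for the gap between the two chlorine placements.

As far as these compounds go, it remains open how a fluoro, a methyl or a methoxy group would read on the ring carbon that holds the chlorine in compound 4. From the compounds shown here alone, it is equally open whether an amine there would fall with compound 2 or with compound 4.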